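Metabolic stability notes: aryl replacement at the pyridine carbon

The compounds below may be only part of what the source reports. "The series", "measured", "known", "first", "only" and "open" are said of these compounds alone.

Measured compounds:
compound 1, `COCC#Cc1cc(C(O)(C(F)(F)F)C(F)(F)F)cnc1N1CCN(S(=O)(=O)c2ccc(N)nc2)CC1`, 15 mL.min-1.g-1
compound 2, `CCn1cc(-c2cc(C(O)(C(F)(F)F)C(F)(F)F)cnc2N2CCN(S(=O)(=O)c3ccc(N)nc3)CC2)cn1`, 20 mL.min-1.g-1
compound 3, `Nc1ccc(S(=O)(=O)N2CCN(c3ncc(C(O)(C(F)(F)F)C(F)(F)F)cc3-c3ccncc3)CC2)cn1`, 15 mL.min-1.g-1

In an ADME assay (liver) for metabolic stability, with Liver microsome (Homo sapiens) as the target, using microsomes and NADPH, with a stated time of 30 min, tested at 1 uM (on this read-out higher numbers stand for fast clearance and lower numbers for slow clearance), compound 3 gives 15 mL.min-1.g-1 and stands level with compound 1 at the digits printed; together these two are the lowest of the three numbers. Its nearest neighbour is compound 1, with no change at the digits printed, and its furthest is compound 2, the step being a 1.3-fold lower number from compound 2 to compound 3 (0.12 log units; within the scatter), which remains within the scatter.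

Compound 4, `Nc1ccc(S(=O)(=O)N2CCN(c3ncc(C(O)(C(F)(F)F)C(F)(F)F)cc3-c3ccc4c(c3)CC(=O)N4)CC2)cn1`, has not yet been run in this assay. It differs from compound 3 in one place: a group of 10 heavy atoms (8 carbon, 1 nitrogen, 1 oxygen; one five-membered non-aromatic ring with 1 hetero atom, one six-membered aromatic ring of carbon only) in place of a group of 6 heavy atoms (5 carbon, 1 nitrogen; one six-membered aromatic ring with 1 hetero atom), on an aromatic carbon. The new group sits on the aromatic carbon ortho to a large group, two atoms from the ring nitrogen and meta to the 2,2,2-trifluoro-1-hydroxy-1-(trifluoromethyl)ethyl group.

Within the data shown here, the steps that bear on this position are a 1.3-fold higher number from compound 1 to compound 2 (0.12 log units; within the scatter), no change at the digits printed from compound 1 to compound 3 (within the scatter) and a 1.3-fold lower number from compound 2 to compound 3 (0.12 log units; within the scatter); every one of them lies within the scatter, so three quite different groups at this carbon have left the clearance where it was. Among the measured compounds shown here, no measured step covers a group of this kind, so no direction beyond the scatter is expected. Compound 4 is therefore estimated at 18 mL.min-1.g-1, with a range from 8 mL.min-1.g-1 to 40 mL.min-1.g-1, a step of a 1.2-fold higher number from compound 3 to compound 4 (0.08 log units; within the scatter) that is expected to stay within the scatter.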

Compound 4, intrinsic clearance in microsomes: < 14 mL.min-1.g-1
Compound 4: only a limit was reported (the forecaster's own chance of this, stated with the estimate: 5%); middle value at least 1.2-fold (0.10 log units) from the limit.
By their numbers in this assay, from the lowest: compounds 1, 3 and 2 (each within the scatter of the next). At a limit, below all of these: compound 4.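

In this assay compound 4 is reported only as a limit and not as a number: the limit of < 14 mL.min-1.g-1 in this assay, at which 1 of the 4 values shown sits.

Set against the earlier compounds, this gives an at least 1.0-fold lower number from compound 3 to compound 4 (0.02 log units; that floor lies within the scatter), an at least 1.0-fold lower number from compound 1 to compound 4 (0.02 log units; that floor lies within the scatter) and an at least 1.4-fold lower number from compound 2 to compound 4 (0.15 log units; that floor lies within the scatter), so every floor stays within the scatter and no real fall in clearance is established. What is new is the kind of group tolerated at this carbon, ortho to a large group: the entering group is the largest of the series here, and the only one with a hydrogen-bond donor, yet the limit leaves no sign of faster clearance than in the compounds with the pyridin-4-yl, 1-ethyl-1H-pyrazol-4-yl or 3-methoxyprop-1-yn-1-yl groups.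

The compounds shown do not separate the contribution of the amide hydrogen from that of the added ring, and a methyl group on the amide nitrogen would address that point. Nor do they tell how this carbon responds to an amine, a carboxylic acid or a longer chain, so the flat clearance holds only for the four groups seen so far.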